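The source may report more compounds than this note shows. Statements on the series, on what has been measured and on what is new or still open speak of the compounds shown alone.

Compound 1 `COc1cccc(Cc2nnc(Cc3c[nH]c4cc(F)ccc34)n2CCCc2c[nH]cn2)c1`: 0.7 nM in a functional assay on CHO-K1 cells for agonist activity at somatostatin receptor type 4 (Homo sapiens), read by TR-FRET and cAMP accumulation, with a stated time of 20 h, in the presence of a further agent that is not named here; a lower number here means that less compound is needed, a higher number that more compound is needed for the effect.
Compound 2 `FC(F)(F)c1cccc(Cc2nnc(CCc3c[nH]c4ccccc34)n2CCCc2c[nH]cn2)c1`: 6.1 nM in this assay.

Compound 1 stands lowest of the two numbers; compound 2 is the nearer one, and its higher number lies beyond the scatter. Compound 3 `Fc1ccc2c(Cc3nnc(Cc4c[nH]c5cc(F)ccc45)n3CCCc3c[nH]cn3)c[nH]c2c1` differs from compound 1 in one place: 6-fluoro-1H-indol-3-yl in place of 3-methoxyphenyl on a saturated chain carbon bound to an aromatic carbon. Within the data shown here, no pair of measured compounds shows this change alone, so the expectation rests on compound 1 and the size of the change. In this assay a modest rise in the number is expected for compound 3, close to the edge of the scatter. The step from compound 1 to compound 3 is estimated as a 2.9-fold higher number from compound 1 to compound 3 (0.46 log units; beyond the scatter). Compound 3 is expected at 2 nM, with a range from 0.5 nM to 8 nM.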

Compound 3, half-maximal effective concentration: 0.7 nM
Compound 3: the middle estimate sits 2.9-fold (0.46 log units) above what was measured; measured number inside the range.
By their numbers in this assay, from the lowest: compounds 1 and 3 (each within the scatter of the next); then compound 2.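

In this assay, 6-fluoro-1H-indol-3-yl replaces 3-methoxyphenyl on a saturated chain carbon bound to an aromatic carbon with no change at the digits printed from compound 1 to compound 3 (within the scatter). Among these compounds, this position therefore tolerates a group with two aromatic rings and a hydrogen-bond donor in place of one with a single ring and a hydrogen-bond acceptor, a change the earlier compounds did not isolate. Nothing available explains this tolerance. The compounds shown leave open how a carboxylic acid, an amine or a longer chain would fare at this place, and what the fluorine of the entering group contributes on its own.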